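Benzyl for isopropyl on sulfur, tested against a limit

The compounds below may be only part of what the source reports. "The series", "measured", "known", "first", "only" and "open" are said of these compounds alone.

In an ADME assay on HFF cells (Homo sapiens) for cytotoxicity, with a stated time of 8 days (a lower number here means that less compound is tolerated, a higher number that more compound is tolerated), compound 1 (`COCCOc1nc(N)nc2c1ncn2/C=C1/CC1(CO)CO`) gives > 300000 nM as a limit, not a number. Compound 2 (`CCCNc1nc(N)nc2c1ncn2/C=C1/CC1(CO)CO`) gives > 300000 nM as a limit too. Compound 3 (`CC(C)Sc1nc(N)nc2c1ncn2/C=C1/CC1(CO)CO`) likewise gives > 300000 nM as a limit, so it has no number of its own. All three share the limit of > 300000 nM in this assay, at which 3 of the 3 values shown sit, and nothing finer.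

Compound 4 (`Nc1nc(SCc2ccccc2)c2ncn(/C=C3/CC3(CO)CO)c2n1`) has benzyl in place of isopropyl on a sulfur, a change that reads benzyl in place of isopropyl on a sulfur when counted out. Three measured steps swap groups on an aromatic carbon, namely a step that the two limits leave unreadable from compound 1 to compound 2 together with a step that the two limits leave unreadable from compound 1 to compound 3 and a step that the two limits leave unreadable from compound 2 to compound 3 as well. None of them has a size to carry over to the new group. In this assay a small step or none is therefore expected, and any readable step is expected toward lower numbers. The expected move is an at least 1.2-fold lower number from compound 3 to compound 4 (0.07 log units; that floor lies within the scatter) and no more. Compound 4 is estimated at 250000 nM with a range from 100000 nM to 300000 nM as its bounds.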

Compound 4, half-maximal cytotoxic concentration: > 300000 nM
Compound 4: only a limit was reported; the forecaster's own chance of this, stated with the estimate: 60%; middle value at least 1.2-fold (0.07 log units) from the limit.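

In this assay compound 4 gives > 300000 nM, a limit and not a number, so no step from compound 1, compound 2 or compound 3 to compound 4 can be read: the limit of > 300000 nM in this assay, at which 4 of the 4 values shown sit.

The compounds shown leave open whether these groups on sulfur, nitrogen or oxygen differ at all in half-maximal cytotoxic concentration.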